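The source may report more compounds than this note shows. Statements on the series, on what has been measured and on what is new or still open speak of the compounds shown alone.

Compound 1 `COC(=O)c1nc(C)n(-c2ccccc2)n1`: > 100000 nM
Compound 2 `COC(=O)c1nc(C)n(-c2cccc(Br)c2)n1`: > 100000 nM

In a functional assay on Jurkat cells (Homo sapiens) for inhibition, read by MTT assay, with a stated time of 72 h (on this read-out higher numbers stand for weaker inhibition of growth and lower numbers for stronger inhibition of growth), compound 1 gives only a limit, > 100000 nM. In this assay compound 2 likewise gives only a limit, > 100000 nM, so compound 2 stands at the edge of the assay with no number of its own. Among the compounds with values here, the one measured step, a step that the two limits leave unreadable from compound 1 to compound 2, cannot be read, since both of its ends sit at the limit of > 100000 nM in this assay, at which 2 of the 2 values shown sit. Compound 3 `COC(=O)c1nc(C)n(-c2cccc(C(F)(F)F)c2)n1` differs from compound 2 by trifluoromethyl in place of bromo on an aromatic carbon. With no readable step to lean on, no shift beyond the scatter is expected, and compound 3 is estimated at 150000 nM (range 40000 nM to 600000 nM), an expected step that the limit leaves unreadable from compound 2 to compound 3.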

Compound 3, concentration for 50% growth inhibition: 10600 nM
Compound 3: the middle estimate sits 14-fold (1.15 log units) above what was measured, outside the stated range (below it).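

In this assay compound 3 is the only compound shown with a measured number, so a change at this ring carbon, meta to a large group, can bring growth inhibition into range. Trifluoromethyl in place of bromo brings an at least 9.4-fold lower number from compound 2 to compound 3 (0.97 log units; beyond the scatter) and, in place of hydrogen, an at least 9.4-fold lower number from compound 1 to compound 3 (0.97 log units; beyond the scatter) while the step with bromo in place of hydrogen cannot be read. Both readable steps are minimum sizes, set by an assay limit: the limit of > 100000 nM in this assay, at which 2 of the 3 values shown sit.

As far as these compounds go, whether a nitrile or a methoxy group at this carbon would serve as well remains open. So does whether trifluoromethyl would give a similar step on another carbon of the ring.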